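A few compounds are considered here, and "the series" means these few. Any claim that something is new, unique, unknown or untested is made for them only; others in the source may bear on it.

Measured so far:
Compound 1, `O=C(Nc1cccc(-n2cc(-c3ccncc3)c(-c3ccc(Cl)c(O)c3)n2)c1)Nc1cccc(C(F)(F)F)c1`, in a functional assay on HCT-15 cells (Homo sapiens) for inhibition, read by sulforhodamine B assay, with a stated time of 48 h (a higher number here means that more compound is tolerated, a lower number that less compound is tolerated), gives > 32500 nM, which is a limit of the assay and not a number.
Compound 2, `COc1cc(-c2nn(-c3cccc(NC(=O)Nc4cc(C(F)(F)F)cc(C(F)(F)F)c4)c3)cc2-c2ccncc2)ccc1Cl`, in this assay gives 4330 nM.

Among the compounds with values here, compound 2 carries the only actual number. For compound 1 there is only (the limit of > 32500 nM in this assay, at which 1 of the 2 values shown sits). Compound 3, `O=C(Nc1cccc(-n2cc(-c3ccncc3)c(-c3ccc(Cl)c(O)c3)n2)c1)Nc1cc(C(F)(F)F)cc(C(F)(F)F)c1`, differs from compound 2 by hydrogen in place of methyl on an oxygen on an aromatic ring. Within the data shown here, no measured pair isolates this change, so its effect is open. In this assay the expected step is a 2.8-fold higher number from compound 2 to compound 3 (0.44 log units; beyond the scatter), toward a more tolerated compound, though with wide uncertainty. Compound 3 is estimated at 12000 nM, expected within 3000 nM to 40000 nM.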

Compound 3, concentration lethal to 50% of the cells: 21200 nM
Beside the measured number, compound 3's estimate is 1.8-fold (0.25 log units) below it, within the range that was stated.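

In this assay the change from methoxy to hydroxy now has a measured size, a 4.9-fold higher number from compound 2 to compound 3 (0.69 log units; beyond the scatter) and this gives a real step at this oxygen, with the methoxy compound the less tolerated of the pair. Trifluoromethyl in place of hydrogen on an aromatic carbon gives an at least 1.5-fold lower number from compound 1 to compound 3 (0.18 log units; that floor lies within the scatter) and only that floor can be read. Compound 1 holds a limit of the assay and not a number: the limit of > 32500 nM in this assay, at which 1 of the 3 values shown sits.

On these data alone, how an ethoxy group or an amine in place of the methoxy would fare remains open. As far as these compounds go, the true size of the trifluoromethyl step also remains open.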